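Notes on compound 4, dibromo analogue of compound 3

The compounds below may be only part of what the source reports. "The series", "measured", "known", "first", "only" and "open" are said of these compounds alone.

Compound 1 `O=C(CSc1nnc(-c2ccncc2)n1-c1ccccc1)N/N=C/c1ccccc1` gives 18600 nM in a functional assay on HepG2 cells (Homo sapiens) for inhibition, read by MTT assay, with a stated time of 48 h; a lower number here means a stronger inhibitor, a higher number a weaker inhibitor. Compound 2 `O=C(CSc1nnc(-c2ccncc2)n1-c1ccccc1)N/N=C/c1cccc(F)c1` gives 24400 nM in this assay, and compound 3 `O=C(CSc1nnc(-c2ccncc2)n1-c1ccccc1)N/N=C/c1ccccc1O` gives 11300 nM. Compound 3 has the lowest of the three numbers; the step that reaches it from the nearer of the other two is a 1.6-fold lower number from compound 1 to compound 3 (0.22 log units; within the scatter), and the step that reaches it from the further one is a 2.2-fold lower number from compound 2 to compound 3 (0.33 log units; beyond the scatter). Compound 4 `O=C(CSc1nnc(-c2ccncc2)n1-c1ccccc1)N/N=C/c1cc(Br)cc(Br)c1O` differs from compound 3 by 3,5-dibromo-2-hydroxyphenyl in place of 2-hydroxyphenyl on a carbon with a double bond to nitrogen. Among the compounds with values here, no measured step adds bromine. Within the data shown here, the only step that adds a halogen, fluoro in place of hydrogen, is a 1.3-fold higher number from compound 1 to compound 2 (0.12 log units; within the scatter); the step that adds hydroxy is a 1.6-fold lower number from compound 1 to compound 3 (0.22 log units; within the scatter); the single step beyond the scatter is modest, a 2.2-fold lower number from compound 2 to compound 3 (0.33 log units; beyond the scatter). Every change so far at this ring has moved the number by little, so for compound 4 no step beyond the scatter is expected, the estimated step being a 1.3-fold lower number from compound 3 to compound 4 (0.10 log units; within the scatter). Compound 4 is estimated at 9000 nM, within a range of 3000 nM to 27000 nM.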

Compound 4, half-maximal inhibitory concentration: 7590 nM
Beside the measured number, compound 4's estimate is 1.2-fold (0.07 log units) above it; low and high end bracket the measured number.
By their numbers in this assay, from the lowest: compounds 4, 3, 1 and 2 (each within the scatter of the next, the first and the last beyond it).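

Within the data shown here, replacing 2-hydroxyphenyl with 3,5-dibromo-2-hydroxyphenyl, the only bromine-bearing group, gives a 1.5-fold lower number from compound 3 to compound 4 (0.17 log units; within the scatter) in this assay, so this position takes the larger group, with 9 heavy atoms against 7, without a change beyond the scatter. Two further steps are beyond the scatter, though both are modest: a 3.2-fold lower number from compound 2 to compound 4 (0.51 log units; beyond the scatter) and a 2.5-fold lower number from compound 1 to compound 4 (0.39 log units; beyond the scatter); the second shows a departure from the phenyl compound that the hydroxy group alone, within the scatter, did not give. No available evidence accounts for these numbers.

Whether both bromine atoms are needed for the separation from the phenyl compound remains open, since a single bromine is not among the compounds shown. Also open, as far as these compounds go, is how an amine or a carboxylic acid on this ring would read in this assay.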